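Varying the Carbamate Ester of Compound 3

The source may hold more compounds than are shown below. What is called first, only, known or untested is meant among the compounds shown, and "the series" means these compounds.

Compounds measured so far:
compound 1, `CN(C)c1ccc(-c2cccc(N)c2)cc1`: 100000 nM
compound 2, `COC(=O)Nc1cccc(-c2ccc(N(C)C)cc2)c1`: 5000 nM
compound 3, `CC(C)OC(=O)Nc1cccc(-c2ccc(N(C)C)cc2)c1`: 82000 nM

All three were tested in an assay on COS-7 cells for inhibition of patatin-like phospholipase domain-containing protein 2 (Mus musculus); a higher number here means a weaker inhibitor, a lower number a stronger inhibitor. Compound 3 stands second highest of the three numbers: its nearest neighbour is compound 1, whose value lies within the scatter of that of compound 3, while compound 2 is the furthest away, as a 16-fold higher number from compound 2 to compound 3 (1.21 log units; beyond the scatter) shows. The two carbamates themselves are set apart by a 20-fold lower number from compound 1 to compound 2 (1.30 log units; beyond the scatter) and a 1.2-fold lower number from compound 1 to compound 3 (0.09 log units; within the scatter), so only the methyl ester moved the number clearly away from the free amine.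

Compound 4, `CN(C)c1ccc(-c2cccc(NC(=O)OCc3ccccc3)c2)cc1`, is the next member of the series. It differs from compound 3 in one place: benzyl in place of isopropyl on an oxygen next to a carbonyl group. Among the measured compounds shown here, the one measured step that bears on this change is a 16-fold higher number from compound 2 to compound 3 (1.21 log units; beyond the scatter), a large move toward weaker inhibition on going from methyl to isopropyl; there is no measured step from isopropyl to benzyl, nor any other benzyl ester. Going further along the same kind of change, compound 4 is expected to land near compound 3 or weaker, so a 1.2-fold higher number from compound 3 to compound 4 (0.09 log units; within the scatter) is the step estimated. Compound 4 is therefore estimated at 100000 nM, with a range from 30000 nM to 300000 nM.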

Compound 4, half-maximal inhibitory concentration: > 200000 nM
Compound 4 gave a limit, no number; the forecaster's own chance of this, stated with the estimate: 30%; at least 2.0-fold (0.30 log units) between middle value and limit.
By their numbers in this assay, from the lowest: compound 2; then compounds 3 and 1 (each within the scatter of the next). At a limit, above all of these: compound 4.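

Compound 4 gave a limit and not a number in this assay: the limit of > 200000 nM in this assay, at which 1 of the 4 values shown sits. Even so, benzyl in place of isopropyl on an oxygen next to a carbonyl group gives an at least 2.4-fold higher number from compound 3 to compound 4 (0.38 log units; beyond the scatter), which shows that this position still responds to a change beyond isopropyl, although compound 3 had already come within the scatter of the free amine, compound 1. As far as these compounds go, measured against the methyl ester, the change is an at least 40-fold higher number from compound 2 to compound 4 (1.60 log units; beyond the scatter), so the number rises along methyl, isopropyl and benzyl among the three carbamates, with none of them going against that order, though the size of the last rise stays open.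

The compounds shown leave open whether ethyl on the same oxygen would read like the methyl of compound 2 or like the isopropyl of compound 3, and whether the rise at benzyl follows from its aromatic ring or from its larger count of carbons, which a cyclohexylmethyl group could help to separate. They also leave open how an amine or a carboxylic acid on the end of a longer chain at this oxygen would read in this assay.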